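Swapping the Proline Carbamate for an Alkyl Chain

The source may hold more compounds than are shown below. What is called first, only, known or untested is meant among the compounds shown, and "the series" means these compounds.

Compound 2 `CC(C)(C)OC(=O)N1CCC[C@H]1C(=O)N1CCC(NS(=O)(=O)c2cc(S(=O)(=O)c3ccccc3)ccc2C(F)(F)F)CC1` gives 60 nM in a functional assay on U2OS cells for antagonist activity at proto-oncogene Wnt-3 (Homo sapiens), read by a luciferase reporter, with a stated time of 18 h; on this read-out higher numbers stand for an effect only at larger amounts of compound and lower numbers for an effect already at smaller amounts.
Compound 1 `O=C(CN1CCNCC1)N1CCC(NS(=O)(=O)c2cc(S(=O)(=O)c3ccccc3)ccc2C(F)(F)F)CC1` gives 250 nM in this assay.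
Compound 3 `O=C([C@@H]1CCCN1C(=O)N1CCOCC1)N1CCC(NS(=O)(=O)c2cc(S(=O)(=O)c3ccccc3)ccc2C(F)(F)F)CC1` gives 280 nM in this assay.

Compound 2 stands lowest of the three numbers, with compound 1 and compound 3 both beyond the scatter above it. Compound 4 `CC(C)(C)CCN1CCC[C@H]1C(=O)N1CCC(NS(=O)(=O)c2cc(S(=O)(=O)c3ccccc3)ccc2C(F)(F)F)CC1` arises from compound 2 by one change: 3,3-dimethylbutyl in place of tert-butoxycarbonyl on an amine nitrogen in a ring. Among the compounds with values here, two measured steps bear on changes at this end of the molecule. a 4.2-fold lower number from compound 1 to compound 2 (0.62 log units; beyond the scatter) shows a modest gain on arriving at 1-(tert-butoxycarbonyl)pyrrolidin-2-yl, and a 4.7-fold higher number from compound 2 to compound 3 (0.67 log units; beyond the scatter) shows a modest loss on swapping tert-butoxy for morpholin-4-yl. Both steps indicate that altering the group on the amine nitrogen in the ring of compound 2 has so far raised the number modestly, though neither step removed the carbonyl, so the direction stays uncertain. For compound 4 a modestly higher number is expected, a 2.5-fold higher number from compound 2 to compound 4 (0.40 log units; beyond the scatter), giving an estimate of 150 nM with a range from 50 nM to 500 nM.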

Compound 4, half-maximal effective concentration: 450 nM
Estimate against measurement, compound 4: 3.0-fold (0.48 log units) below, within the range that was stated.
By their numbers in this assay, from the lowest: compound 2; then compounds 1, 3 and 4 (each within the scatter of the next).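

Within the data shown here, the 3,3-dimethylbutyl chain is the first group here to remove the carbonyl from the amine nitrogen in the ring, and it gives a 7.5-fold higher number from compound 2 to compound 4 (0.88 log units; beyond the scatter). Its other steps lie within the scatter, a 1.6-fold higher number from compound 3 to compound 4 (0.21 log units; within the scatter) and a 1.8-fold higher number from compound 1 to compound 4 (0.26 log units; within the scatter), so these values do not separate these compounds. No supporting measurement explains the result.

Open, going by these compounds, is whether a simple acetyl group, which keeps the carbonyl but lacks the tert-butoxy part, would retain the lower number. Also open, on these data alone, is how a shorter chain or a carboxylic acid at this nitrogen would compare.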